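A few compounds are considered here, and "the series" means these few. Any claim that something is new, unique, unknown or untested is made for them only; others in the source may bear on it.

Measured compounds and their numbers in an ADME assay on the whole organism with Oryza sativa as the target, tested at 1 uM; a higher number here means a weaker effect of the compound at the concentration tested, a lower number a stronger effect:

Compound 1, `C[C@@H](NC(=O)Nc1cccc(F)c1)c1ccccc1`, gives 95%.
Compound 2, `C[C@H](NC(=O)Nc1ccc(F)cc1)c1ccccc1`, gives 97%.
Compound 3, `C[C@H](NC(=O)Nc1ccc(F)cc1F)c1ccccc1`, gives 100%.

Compound 1 and compound 2 are built from the same atoms joined differently; the difference between the two cores is not broken down here. Their two numbers in this assay lie within the usual scatter of each other, so nothing can be said about an order between them. Compound 2 and compound 3 differ in one place, (fluoro in place of hydrogen on an aromatic carbon), and that change gave a number 3 percentage points higher from compound 2 to compound 3 (within the scatter), a step within the scatter.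

The compound not yet measured is compound 4, `C[C@@H](NC(=O)Nc1cc(F)ccc1F)c1ccccc1`. It differs from compound 1 by fluoro in place of hydrogen on an aromatic carbon. For the measured compounds named here, this is the same kind of change as the one from compound 2 to compound 3, but not the same: in compound 3 the entering fluoro sits meta to a fluoro group, whereas in compound 4 it sits para to a fluoro group. Going by the values given here, because the only example of this kind of change, a number 3 percentage points higher from compound 2 to compound 3 (within the scatter), stayed within the scatter, the expected step for compound 4 is also small, a number 2 percentage points higher from compound 1 to compound 4 (within the scatter). The estimate for compound 4 in this assay is therefore 97%, with a likely range from 89% to 100%.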

Compound 4, a percentage reported as activity, at one concentration (the size of the read-out at that concentration, not a potency): 100%
Beside the measured number, compound 4's estimate is 3 percentage points below it, within the range that was stated.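

In this assay, putting fluoro in place of hydrogen on an aromatic carbon gave a number 5 percentage points higher from compound 1 to compound 4 (within the scatter), so this second example of the change, like the first, did not move the number by more than repeated measurements usually differ. Set side by side, the two examples do not differ, and nothing here suggests that the change behaves differently on the two cores: the same change on two cores in this assay, a number 3 percentage points higher (within the scatter) from compound 2 to compound 3 and a number 5 percentage points higher (within the scatter) from compound 1 to compound 4, 2 percentage points apart, within the scatter of two such steps

This is weak support for carrying the change from one core to another, however: neither step can be told apart from no effect, the entering fluoro does not sit in the same place in compound 3 and compound 4, and two examples cannot separate that difference from the difference between the cores.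

Every compound shown carries only fluoro groups on the fluorinated aromatic ring, which leaves open what a chlorine, a methoxy group, an amine or a carboxylic acid in that place would do to the number in this assay. No step shown lies beyond the scatter, and whether any change to this series can give a number clearly apart from these also remains open.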